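Aryl ketones on a chromene core: towards a nitrophenyl analogue

The source may hold more compounds than are shown below. What is called first, only, known or untested is meant among the compounds shown, and "the series" means these compounds.

The series shares one core, varied only at the carbonyl carbon. Compound 1 `CC(=O)c1ccc2c(c1)C(n1ccccc1=O)=CC(C)(C)O2` carries a methyl there and in a functional assay (aorta) with Rattus norvegicus as the target (a lower number here means a less potent compound, a higher number a more potent compound, by a factor of ten per unit of this negative logarithm), compound 1 gives 7.37. Compound 2 `COc1ccc(C(=O)c2ccc3c(c2)C(n2ccccc2=O)=CC(C)(C)O3)cc1` carries a 4-methoxyphenyl and in this assay compound 2 gives 6.15. Compound 3 `CC1(C)C=C(n2ccccc2=O)c2cc(C(=O)c3cccs3)ccc2O1` carries a thiophen-2-yl and in this assay compound 3 gives 6.4, which places it second of the three numbers, close to compound 2 and well short of compound 1. The steps show a number 1.22 log units lower from compound 1 to compound 2 (beyond the scatter) and a number 0.97 log units lower from compound 1 to compound 3 (beyond the scatter), while a number 0.25 log units higher from compound 2 to compound 3 (within the scatter).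

Compound 4 `CC1(C)C=C(n2ccccc2=O)c2cc(C(=O)c3ccc([N+](=O)[O-])cc3)ccc2O1` is unmeasured. Relative to compound 3 the change is 4-nitrophenyl in place of thiophen-2-yl on a carbonyl carbon. Among the compounds with values here, the one step that bears on it, a number 0.25 log units higher from compound 2 to compound 3 (within the scatter), lies within the scatter, and it is the only exchange of one ring for another at this position that the data contain. Compound 4 is therefore expected to stay near compound 3, with a number 0.10 log units lower from compound 3 to compound 4 (within the scatter) as the estimated step. Compound 4 is estimated at 6.3 in this assay, with a range from 5.7 to 6.9.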

Compound 4, logarithm of the reciprocal of the active concentration, log(1/C): 6.2
Compound 4: middle estimate off by 0.10 log units, on the high side; measured number inside the range.
By their numbers in this assay, from the lowest: compounds 2, 4 and 3 (each within the scatter of the next); then compound 1.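

With a number 0.20 log units lower from compound 3 to compound 4 (within the scatter) and a number 0.05 log units higher from compound 2 to compound 4 (within the scatter) in this assay, the thiophen-2-yl, 4-methoxyphenyl and 4-nitrophenyl ketones now read alike, and nitro in place of methoxy on an aromatic carbon makes no difference that can be read. With a number 1.17 log units lower from compound 1 to compound 4 (beyond the scatter) as well, 4-nitrophenyl joins the other two rings well short of the methyl of compound 1. Among these four compounds, the divide at this position therefore runs between methyl and a ring on the carbonyl carbon, and not among the rings shown.

Still open, on these data alone, is whether a longer chain such as propyl in place of that methyl, or an amine on the phenyl ring, would stay near compound 1 or fall with the ring compounds. Nothing available accounts for the gap between methyl and the rings.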